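Same Amine Change Repeated on Two Related Cores

A few compounds are considered here, and "the series" means these few. Any claim that something is new, unique, unknown or untested is made for them only; others in the source may bear on it.

Compound 1, `CNCC(=O)Nc1cc(OC)ccc1C(=O)c1ccc(OC)c2c1OC(C)(C)C=C2`, and compound 2, `CCNCC(=O)Nc1cc(OC)ccc1C(=O)c1ccc(OC)c2c1OC(C)(C)C=C2`, are built on one shared core. In a functional assay on A549 cells (Homo sapiens) for antiproliferative activity, read by MTT assay, with a stated time of 48 h (on this read-out higher numbers stand for weaker inhibition and lower numbers for stronger inhibition), compound 1 gives 620 nM, and compound 2 gives 1050 nM. Among the compounds with values here, the only structural change between them is methyl in place of hydrogen on a saturated chain carbon bound to an amine nitrogen. That change produced a 1.7-fold higher number from compound 1 to compound 2 (0.23 log units; within the scatter), so the two compounds cannot be told apart with confidence on this read-out.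

Compound 3, `C=C(c1ccc(OC)cc1NC(=O)CNC)c1ccc(OC)c2c1C=CC(C)(C)O2`, stands on a second core; the difference between the two cores is not broken down here. In this assay compound 3 gives 320 nM. Its number is close to that of compound 1, and the gap to compound 2 is wide enough to count as a real difference.

Compound 4, `C=C(c1ccc(OC)cc1NC(=O)CNCC)c1ccc(OC)c2c1C=CC(C)(C)O2`, has not yet been measured. Within the data shown here, it differs from compound 3 by methyl in place of hydrogen on a saturated chain carbon bound to an amine nitrogen, which is the same change, at the same place, as the one that turns compound 1 into compound 2. Since the surroundings of the place are described in identical words for both pairs, the earlier step is the natural guide.

A step of about the same size is expected from the same change on the second core, a 1.7-fold higher number from compound 3 to compound 4 (0.23 log units; within the scatter), because the first core gave a 1.7-fold higher number from compound 1 to compound 2 (0.23 log units; within the scatter). Among the measured compounds shown here, with only one earlier example, the uncertainty is wide. Compound 4 is therefore estimated at 540 nM, within a range from 250 nM to 1200 nM.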

Compound 4, half-maximal inhibitory concentration: 1870 nM
Compound 4: middle estimate off by 3.5-fold (0.54 log units), on the low side, and the stated range ends below it.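

On the second core, going from methylamino to ethylamino gave a 5.8-fold higher number from compound 3 to compound 4 (0.77 log units; beyond the scatter) in this assay, so here the extra methyl comes with a clearly weaker result. Set beside the step on the first core, the same change did not keep its size from one core to the other: the same change on two cores in this assay, a 1.7-fold higher number (0.23 log units; within the scatter) from compound 1 to compound 2 and a 5.8-fold higher number (0.77 log units; beyond the scatter) from compound 3 to compound 4, 3.5-fold (0.54 log units) apart, beyond the scatter of two such steps. This shows that in this series a step read on one core cannot be carried to another as a fixed number, even when the change and its place are described in identical words; it does not show what in the two cores sets the steps apart, and two pairs are too few to say how the change would behave on any further core.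

The compounds shown stop at methylamino and ethylamino, so it remains open how a longer chain such as propylamino, a primary amine or a ring amine such as piperidine would fare on either core. Going by these compounds, it is also open whether a larger step on the second core would appear again with such groups, or would be seen in cells other than these.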